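Capping the Phenol: Expected Cytotoxicity of Compound 4

The compounds below may be only part of what the source reports. "The series", "measured", "known", "first", "only" and "open" are said of these compounds alone.

Compound 1, `COc1cc(-n2c(-c3ccccc3)csc2=S)cc(OC)c1OC`: 52 ug/mL
Compound 2, `COc1cc(-n2c(-c3ccc(Cl)cc3Cl)csc2=S)cc(OC)c1OC`: 49 ug/mL
Compound 3, `COc1cc(-n2c(-c3ccc(O)cc3)csc2=S)cc(OC)c1OC`: 22.9 ug/mL

All three were tested in a functional assay on MDA-MB-231 cells (Homo sapiens) for cytotoxicity, read by MTT assay, with a stated time of 48 h; on this read-out higher numbers stand for weaker inhibition and lower numbers for stronger inhibition. Compound 3 gives the lowest number of the three: the step of a 2.3-fold lower number from compound 1 to compound 3 (0.36 log units; beyond the scatter) and the step of a 2.1-fold lower number from compound 2 to compound 3 (0.33 log units; beyond the scatter) both lie beyond the scatter, whereas the step of a 1.1-fold lower number from compound 1 to compound 2 (0.03 log units; within the scatter) does not. Compound 4, `COc1ccc(-c2csc(=S)n2-c2cc(OC)c(OC)c(OC)c2)cc1`, differs from compound 3 by methyl in place of hydrogen on an oxygen on an aromatic ring. Within the data shown here, no measured step touches this oxygen, so the only guide is that the two steps introducing the hydroxy group were modest gains, and it is uncertain whether the methyl keeps them. A step of a 1.5-fold higher number from compound 3 to compound 4 (0.18 log units; within the scatter) is therefore expected, towards weaker inhibition. Compound 4 is estimated at 35 ug/mL, within 15 ug/mL to 75 ug/mL.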

Compound 4, half-maximal inhibitory concentration: 53.8 ug/mL
For compound 4 the middle estimate is 1.5-fold (0.19 log units) below the measured one; measured number inside the range.
By their numbers in this assay, from the lowest: compound 3; then compounds 2, 1 and 4 (each within the scatter of the next).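

Putting methyl on this oxygen cancels what the free hydroxy group gave in this assay (a 2.3-fold higher number from compound 3 to compound 4 (0.37 log units; beyond the scatter)). The methoxy compound cannot be told apart from the compounds lacking a hydroxy group (a 1.0-fold higher number from compound 1 to compound 4 (0.01 log units; within the scatter); a 1.1-fold higher number from compound 2 to compound 4 (0.04 log units; within the scatter)), so among these compounds an oxygen on the ring is not enough, and the lower number goes with the hydroxy group's hydrogen. Nothing available explains why this is so. On these data alone, whether an amine in place of the hydroxy group would keep the lower number remains open. So does the result of moving the hydroxy group elsewhere on that phenyl ring.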